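Trading a benzyl link for an amide on the core

The compounds below may be only part of what the source reports. "The series", "measured", "known", "first", "only" and "open" are said of these compounds alone.

Compound 1 `CON(C)C(=O)c1ccc([C@H](C)NC(=O)c2c(Cc3ccc(F)cc3)sc3c2CCOC3)cc1` gives 187 nM in a functional assay on CHO/Galpha16 cells for antagonist activity at prostaglandin E2 receptor EP4 subtype (Homo sapiens), read by calcium flux, with a stated time of 15 min; a higher number here means a weaker inhibitor, a lower number a stronger inhibitor.
Compound 2 `CC(=O)N1CCc2c(sc(CCc3ccc(F)cc3)c2C(=O)N[C@@H](C)c2ccc(C(=O)O)cc2)C1` reaches only a limit in this assay, namely > 1000 nM.
Compound 3 `C[C@H](NC(=O)c1c(Cc2cccc(F)c2)sc2c1CCOC2)c1ccc(C(=O)O)cc1` gives 5.1 nM in this assay.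

Of the two measured numbers, compound 3 holds the lower one, and the number of compound 1 lies far above it, well beyond the scatter. Compound 4 `C[C@H](NC(=O)c1c(NC(=O)c2ccc(F)cc2)sc2c1CCOC2)c1ccc(C(=O)O)cc1` is made from compound 3 by one change: ((4-fluorophenyl)carbonyl)amino in place of 3-fluorobenzyl on an aromatic carbon. Within the data shown here, no measured pair shows a change of this kind, so the size of its effect is uncertain. A modest weakening is expected, a step of a 2.9-fold higher number from compound 3 to compound 4 (0.47 log units; beyond the scatter) in this assay, larger than the scatter but far from the limit. Compound 4 is therefore estimated at 15 nM, with a range from 3 nM to 80 nM.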

Compound 4, half-maximal inhibitory concentration: > 1000 nM
Compound 4 ended at the assay's limit (the forecaster's own chance of this, stated with the estimate: 10%); at least 66-fold (1.82 log units) between middle value and limit.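

Among these compounds, on the aromatic carbon next to the ring sulfur, the earlier compounds showed no single change, and this pair shows that the group held there can decide activity: ((4-fluorophenyl)carbonyl)amino in place of 3-fluorobenzyl gives an at least 190-fold higher number from compound 3 to compound 4 (2.29 log units; beyond the scatter). Compound 4 reaches only a limit, > 1000 nM, so this step gives no exact size: the limit of > 1000 nM in this assay, at which 2 of the 4 values shown sit.

The change alters both the link to the ring and the place of the fluorine, and these compounds do not separate the two. On these data alone, how a plain amine link or a longer carbon chain at this position would behave also stays open.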